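Notes on amide substituents and endonuclease inhibition

The source may hold more compounds than are shown below. What is called first, only, known or untested is meant among the compounds shown, and "the series" means these compounds.

Measured compounds:
- compound 1, `CC(=O)NCCNC(=O)c1nc(-c2cccs2)[nH]c(=O)c1O`: in an assay on isolated protein for inhibition of Flap endonuclease 1 (Homo sapiens) (on this read-out higher numbers stand for weaker inhibition and lower numbers for stronger inhibition), compound 1 gives 5000 nM
- compound 2, `O=C(Nc1ccc(F)cc1)c1nc(-c2cccs2)[nH]c(=O)c1O`: in this assay compound 2 gives 10500 nM

Within the data shown here, compound 2 stands at the higher of the two numbers so far; the only measured step is a 2.1-fold higher number from compound 1 to compound 2 (0.32 log units; beyond the scatter), where 4-fluorophenyl replaces 2-acetamidoethyl on the amide-type nitrogen. That step exchanges a chain for an aromatic ring, so it bears only indirectly on the next change, which keeps an aromatic ring in place.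

Compound 3, `O=C(Nc1cccnc1)c1nc(-c2cccs2)[nH]c(=O)c1O`, differs from compound 2 by pyridin-3-yl in place of 4-fluorophenyl on an amide-type nitrogen. Among the measured compounds shown here, no measured step exchanges one six-membered aromatic ring for another on this nitrogen, so the expectation rests on the size of the single known step, which was itself modest. On that basis the expected step is small, a 1.2-fold lower number from compound 2 to compound 3 (0.07 log units; within the scatter), with no firm direction and quite possibly inside the scatter. For compound 3 the estimate in this assay is 9000 nM, with a range from 3500 nM to 25000 nM.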

Compound 3, half-maximal inhibitory concentration: 8600 nM
The estimate for compound 3 lay 1.0-fold (0.02 log units) above the measured number, and the stated range covers the measured number.
By their numbers in this assay, from the lowest: compounds 1, 3 and 2 (each within the scatter of the next, the first and the last beyond it).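

In this assay, pyridin-3-yl in place of 4-fluorophenyl on the amide-type nitrogen gives a 1.2-fold lower number from compound 2 to compound 3 (0.09 log units; within the scatter) and so, in this first exchange of one six-membered aromatic ring for another, the loss of fluorine and the entry of a ring nitrogen leave compound 2 and compound 3 unseparated. The comparison with the chain also gains a second case: pyridin-3-yl in place of 2-acetamidoethyl gives a 1.7-fold higher number from compound 1 to compound 3 (0.24 log units; within the scatter) and thus, unlike the earlier step to 4-fluorophenyl, this exchange of the chain for an aromatic ring stays within the scatter, so a gap beyond the scatter is not general to such exchanges. Nothing available on these compounds bears on why the numbers fall as they do.

Still open, on these data alone, is whether a group of another kind on this nitrogen, such as a longer chain ending in an amine or a carboxylic acid, would move the number beyond the scatter of all three compounds. Also open, as far as these compounds go, is whether pyridin-2-yl or pyridin-4-yl would match pyridin-3-yl, and whether a benzyl group would behave like the aromatic rings or like the chain.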